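From 2-phenylpropyl to 4-fluorobenzyl

The source may report more compounds than this note shows. Statements on the series, on what has been measured and on what is new or still open speak of the compounds shown alone.

Compound 3 (`C=CS(=O)(=O)NC/C=C/c1cc(OC)cc(O)c1C(=O)OCC(C)c1ccccc1`) stands lowest of three compounds in a functional assay on THP-1 cells (Homo sapiens) for inhibition, read by luminescence, with a stated time of 72 h, tested at 5 uM (a higher number here means more inhibition of growth at the concentration tested, a lower number less inhibition of growth), with 5.6% while compound 1 (`C=CS(=O)(=O)NC/C=C/c1cc(OC)cc(O)c1C(=O)OC(C)C`) gives 19.9% and compound 2 (`C=CS(=O)(=O)NC/C=C/c1cc(OC)cc(O)c1C(=O)OCC1CCCCC1`) gives 26.5% on the same core. Compound 4 (`C=CS(=O)(=O)NC/C=C/c1cc(OC)cc(O)c1C(=O)OCc1ccc(F)cc1`) has 4-fluorophenyl in place of 1-phenylethyl on a saturated chain carbon bound to an oxygen next to a carbonyl group. Cut one bond further out, the same change reads 2-phenylpropyl to 4-fluorobenzyl.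

Among the compounds with values here, no measured step makes this exchange, so the evidence is indirect. The steps of a number 14.3 percentage points lower from compound 1 to compound 3 (beyond the scatter) and a number 20.9 percentage points lower from compound 2 to compound 3 (beyond the scatter) bear on it most, since both end at the group that now leaves. The step of a number 6.6 percentage points higher from compound 1 to compound 2 (within the scatter) gives no separation between isopropyl and cyclohexylmethyl. Leaving the 2-phenylpropyl group might therefore recover part of that modest loss, but compound 4 keeps a six-membered aromatic ring, and the data do not show how it will compare. A modest rise is expected, and the estimate is a number 10.4 percentage points higher from compound 3 to compound 4 (beyond the scatter) at the middle of the range. Compound 4 is estimated at 16% in this assay with an expected range from 3% to 32% around that middle.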

Compound 4, percent growth inhibition at one concentration: 41.7%
Compound 4: middle estimate off by 25.7 percentage points, on the low side; the whole stated range lies below it.
By their numbers in this assay, from the lowest: compound 3; then compounds 1 and 2 (each within the scatter of the next); then compound 4.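

In this assay, the step of a number 36.1 percentage points higher from compound 3 to compound 4 (beyond the scatter) is large, and the 4-fluorobenzyl group also stands clear of the two other groups, with a number 15.2 percentage points higher from compound 2 to compound 4 (beyond the scatter) and a number 21.8 percentage points higher from compound 1 to compound 4 (beyond the scatter). The earlier compounds shown here showed only a drop with 2-phenylpropyl and no separation between isopropyl and cyclohexylmethyl; compound 4 shows that this place on an oxygen next to a carbonyl group can give a number beyond the scatter of all three, and that a six-membered aromatic ring in the group does not by itself go with a low number. Nothing among the data given here accounts for this rise.

What the compounds shown leave open is which part of the change from 2-phenylpropyl to 4-fluorobenzyl carries the step, since the fluorine and the shape of the chain differ together between compound 3 and compound 4. An unsubstituted benzyl group would separate these two parts, and a 4-chlorobenzyl or 4-methoxybenzyl group would show whether the fluorine can be exchanged at all.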